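The source may report more compounds than this note shows. Statements on the series, on what has been measured and on what is new or still open speak of the compounds shown alone.

Of the compounds shown here, three have been tested in a functional assay on SW1573 cells (Homo sapiens) for antiproliferative activity, read by sulforhodamine B assay, with a stated time of 48 h; a lower number here means a stronger inhibitor of growth, a higher number a weaker inhibitor of growth. Compound 1 `CCCCC(C#CC(=O)OC)O/C=C/C(=O)OC` gives 240 nM, the lowest number among them. Compound 2 `C#CC(O/C=C/C(=O)OC)c1ccccc1` gives 31000 nM, a much higher number and a gap well beyond the scatter. Compound 3 `CC1CCC(C(C)C)C(OC(=O)C#CC(O/C=C/C(=O)OC2CC(C)CCC2C(C)C)C(C)C)C1` reached only a limit of the assay, > 100000 nM, so it has no exact number.

The next compound to be tested is compound 4 `COC(=O)C#CC(O/C=C/C(=O)OC)C1CCCCC1`. It departs from compound 1 in one place, with cyclohexyl in place of butyl on a saturated chain carbon bound to an oxygen on an unsaturated carbon and a triple-bonded carbon. Going by the values given here, no two measured compounds differ in only one place, so the data do not isolate this change, and compound 2 does not set its size. The starting point is therefore compound 1 at 240 nM. In this assay, among the compounds with values here, a small move toward a higher number is expected, near the edge of the scatter rather than a gap like the one seen with compound 2. The expected step is a 2.1-fold higher number from compound 1 to compound 4 (0.32 log units; beyond the scatter). For compound 4 the estimated value is 500 nM, with an expected range from 120 nM to 2500 nM.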

Compound 4, concentration for 50% growth inhibition: 2100 nM
The estimate for compound 4 lay 4.2-fold (0.62 log units) below the measured number; the range from low to high includes it.
By their numbers in this assay, from the lowest: compound 1; then compound 4; then compound 2. At a limit, above all of these: compound 3.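

In this assay, going by these compounds alone, placing cyclohexyl in place of butyl on a saturated chain carbon bound to an oxygen on an unsaturated carbon and a triple-bonded carbon gives an 8.8-fold higher number from compound 1 to compound 4 (0.94 log units; beyond the scatter), the first step that isolates a single change. This position is therefore sensitive to the group it carries, although compound 4 still gives an exact value of 2100 nM rather than a limit, so a six-membered non-aromatic ring of carbon only is tolerated here with weaker growth inhibition than butyl gives. Nothing among the data shown explains this step.

Butyl and cyclohexyl differ both in the ring and in the number of carbons, so the compounds shown leave open which of the two goes with the higher number, a question that a straight hexyl chain at this position could help to separate. Also open, as far as these compounds go, is how a smaller ring such as cyclopropyl, or a chain ending in an amine or a carboxylic acid, would read on this same carbon.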